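The source may report more compounds than this note shows. Statements on the series, on what has been measured and on what is new or still open speak of the compounds shown alone.

Compound 1 `Cc1n[nH]c2c1C(c1ccc(N(C)C)cc1)C(C(=O)NN)=C(N)N2` gives 51300 nM
Compound 2 `Cc1n[nH]c2c1C(c1ccc(N(C)C)cc1)C(C(=O)NNC(N)=S)=C(N)N2` gives 6260 nM

In a functional assay on HeLa cells (Homo sapiens) for cytotoxicity, read by MTT assay, with a stated time of 48 h (on this read-out higher numbers stand for weaker inhibition and lower numbers for stronger inhibition), compound 2 stands lowest of the two, at 6260 nM. Compound 3 `Cc1n[nH]c2c1C(c1ccc(N(C)C)cc1)C(C(=O)n1ncc(C#N)c1N)=C(N)N2` has not yet been measured. Its structure differs by a group of 8 heavy atoms (4 carbon, 4 nitrogen; one five-membered aromatic ring with 2 hetero atoms) in place of a group of 5 heavy atoms (1 carbon, 3 nitrogen, 1 sulfur; no ring), on a carbonyl carbon. For the measured compounds named here, only one measured step bears on this change, an 8.2-fold lower number from compound 1 to compound 2 (0.91 log units; beyond the scatter), which was modest and also altered the group on the carbonyl carbon. The entering ring has no counterpart in either measured compound, so the evidence is thin. Going by the values given here, a modest rise in this assay is expected, no larger than that step. The expected step is a 2.1-fold higher number from compound 2 to compound 3 (0.32 log units; beyond the scatter). For compound 3 the estimate is 13000 nM, with an expected range of 3500 nM to 50000 nM.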

Compound 3, half-maximal inhibitory concentration: 60200 nM
The estimate for compound 3 lay 4.6-fold (0.67 log units) below the measured number; the whole stated range lies below it.
By their numbers in this assay, from the lowest: compound 2; then compounds 1 and 3 (each within the scatter of the next).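

Placing 5-amino-4-cyano-1H-pyrazol-1-yl on the carbonyl carbon in this assay brings a 9.6-fold higher number from compound 2 to compound 3 (0.98 log units; beyond the scatter) and leaves a 1.2-fold higher number from compound 1 to compound 3 (0.07 log units; within the scatter) as the comparison with the simplest group shown. The lower number at this position did not carry over to a ring: of the three groups shown, only the sulfur-bearing group of compound 2 stands apart. As far as these compounds go, whether a simple amine or a carboxylic acid on this carbonyl carbon would match compound 2 stays open, as does the part played by the nitrile or the amino group of the entering ring. Nothing shown explains why these groups differ.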